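The compounds below may be only part of what the source reports. "The series", "measured", "known", "first", "only" and "open" are said of these compounds alone.

In an ADME assay on microsomes from liver (Rattus norvegicus) for metabolic stability; a higher number here means faster removal of the compound, a lower number slower removal:
- Compound 1 `CNc1nc(NC)nc(NC2(C#N)CCCCC2)n1`: 210 mL/min/kg
- Compound 2 `CNc1nc(NC2(C#N)CCCCC2)nc(-n2cnc(C)n2)n1`: > 276 mL/min/kg

The entry for compound 2 is a limit of the assay, not a number: the limit of > 276 mL/min/kg in this assay, at which 1 of the 2 values shown sits. Compound 3 `CNc1nc(C#N)nc(NC2(C#N)CCCCC2)n1` has cyano in place of 3-methyl-1H-1,2,4-triazol-1-yl on an aromatic carbon. For the measured compounds named here, the only measured step, an at least 1.3-fold higher number from compound 1 to compound 2 (0.11 log units; that floor lies within the scatter), brought that triazolyl group in place of methylamino, and its floor lies within the scatter. It therefore gives no firm size or direction for the new change. Going by the values given here, the sole true number is the 210 mL/min/kg of compound 1, so clearance of similar height is expected. The expected change is an at least 1.4-fold lower number from compound 2 to compound 3 (0.16 log units; that floor lies within the scatter), a downward step of uncertain size. For compound 3 the estimate is 190 mL/min/kg, with an expected range of 90 mL/min/kg to 280 mL/min/kg.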

Compound 3, clearance: 122 mL/min/kg
Compound 3: the middle estimate sits 1.6-fold (0.19 log units) above what was measured; the range from low to high includes it.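

In this assay, for the compounds shown here, cyano in place of the 3-methyl-1H-1,2,4-triazol-1-yl group gives the first step at this position that clears the usual scatter: an at least 2.2-fold lower number from compound 2 to compound 3 (0.35 log units; beyond the scatter). From the compounds shown here alone, the entry for compound 2 is a limit and not a number, so the full size of this step is unknown: the limit of > 276 mL/min/kg in this assay, at which 1 of the 3 values shown sits. Cyano in place of methylamino gives a 1.7-fold lower number from compound 1 to compound 3 (0.24 log units; within the scatter), so these two groups cannot be told apart here.

Going by these compounds, how a methoxy group, a chlorine atom or a primary amine would behave at this position stays open. So does whether cyano has the same effect on a different core.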